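Three Variations on a Nucleoside Side Chain, and a Fourth

This account rests on a few compounds, and the source may have more. Where it says the series, first, only, none or still open, it means among the compounds named here.

Compound 1 `CN(Cc1ccccc1)Cc1ncnc2c1ncn2[C@@H]1O[C@H](CO)[C@@H](O)[C@H]1O` was tested in a functional assay on HL-60 cells (Homo sapiens) for inhibition, with a stated time of 72 h (a higher number here means a weaker inhibitor, a lower number a stronger inhibitor), where compound 1 gives 5600 nM. Among the three numbers recorded so far this is the lowest. Compound 3 `OC[C@H]1O[C@@H](n2cnc3c(Cn4ccc5ccccc54)ncnc32)[C@H](O)[C@@H]1O` gives 5700 nM in this assay, and the step of a 1.0-fold higher number from compound 1 to compound 3 (0.01 log units; within the scatter) stays within the scatter. Compound 2 `COCc1ncnc2c1ncn2[C@@H]1O[C@H](CO)[C@@H](O)[C@H]1O` gives 13000 nM in this assay, and the step of a 2.3-fold higher number from compound 1 to compound 2 (0.37 log units; beyond the scatter) is modest but lies beyond the scatter.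

Compound 4 `CC(C)N(Cc1ncnc2c1ncn2[C@@H]1O[C@H](CO)[C@@H](O)[C@H]1O)C(C)C` remains to be measured in this assay. It differs from compound 1 in one place: diisopropylamino in place of benzyl(methyl)amino on a saturated chain carbon bound to an aromatic carbon

Within the data shown here, two measured steps bear on this change. The step of a 2.3-fold higher number from compound 1 to compound 2 (0.37 log units; beyond the scatter) also removes the six-membered aromatic ring from the side chain and gives a modest rise, whereas the step of a 1.0-fold higher number from compound 1 to compound 3 (0.01 log units; within the scatter) keeps a ring and shows no change beyond the scatter. Compound 4 likewise loses the ring, so a modest rise in the number is expected, on the order of a 1.6-fold higher number from compound 1 to compound 4 (0.21 log units; within the scatter). Compound 4 is therefore estimated at 9000 nM in this assay, within a range from 4000 nM to 20000 nM.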

Compound 4, half-maximal inhibitory concentration: 13000 nM
Compound 4: the middle estimate sits 1.4-fold (0.16 log units) below what was measured; low and high end bracket the measured number.
By their numbers in this assay, from the lowest: compounds 1 and 3 (each within the scatter of the next); then compounds 2 and 4 (each within the scatter of the next).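

Replacing benzyl(methyl)amino with diisopropylamino in this assay gives a 2.3-fold higher number from compound 1 to compound 4 (0.37 log units; beyond the scatter) and, measured against the 1H-indol-1-yl group, a 2.3-fold higher number from compound 3 to compound 4 (0.36 log units; beyond the scatter), so keeping an amine nitrogen on this saturated chain carbon does not by itself keep the number low. The comparison with the methoxy compound shows no change at the digits printed from compound 2 to compound 4 (within the scatter), which places an amine without a ring level with an ether without a ring. Across these four compounds, the two side chains carrying an aromatic ring give the lower numbers and no compound goes against this pairing, but nothing available explains it.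

As far as these compounds go, it remains open whether the ring or the rest of the group matters more. A dibenzylamino group or a benzyloxy group on this carbon would help separate the two.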